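The source may report more compounds than this note shows. Statements on the series, on what has been measured and on what is new or still open speak of the compounds shown alone.

Measured so far:
Compound 1 `C=CC1=C(C(=O)NCc2ccc(Cl)cc2)C(c2ccc(OC)cc2)OC1`: > 100000 nM
Compound 2 `C=CC1=C(C(=O)Nc2ccccc2OC)C(c2ccc(F)cc2)OC1`: > 100000 nM

In a functional assay on SW480 cells (Homo sapiens) for cytotoxicity, read by MTT assay, with a stated time of 24 h (on this read-out higher numbers stand for weaker inhibition and lower numbers for stronger inhibition), compound 2 gives > 100000 nM, which is a limit of the assay rather than a number. Compound 1 also gives > 100000 nM in this assay, again a limit. Both measured compounds therefore sit at the limit of > 100000 nM in this assay, at which 2 of the 2 values shown sit.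

Compound 3 `C=CC1=C(C(=O)Nc2cccc(C)c2)C(c2ccc(F)cc2)OC1` has not yet been measured. Its difference from compound 2 is 3-methylphenyl in place of 2-methoxyphenyl on an amide-type nitrogen. Among the measured compounds shown here, no measured step covers this change, so the expectation is a step of no size beyond the usual scatter: from compound 2 to compound 3 the expected step is a step that the limit leaves unreadable from compound 2 to compound 3. Compound 3 is thus estimated at 150000 nM, with a range from 60000 nM to 400000 nM, most likely reported again only as a limit.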

Compound 3, half-maximal inhibitory concentration: > 100000 nM
Compound 3: only a limit was reported; the forecaster's own chance of this, stated with the estimate: 85%; the middle value does not contradict the limit.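

Among the compounds shown here, compound 2 and compound 3 both end at a limit of the assay rather than a number, so no step between them can be read. The compounds shown leave open whether changing the group on the amide-type nitrogen makes any difference to cytotoxicity.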